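Swapping Ethynyl for Phenyl on the Shared Core

This account rests on a few compounds, and the source may have more. Where it says the series, first, only, none or still open, it means among the compounds named here.

Three measured compounds share one core and differ only in one group on it. Compound 1 `C#Cc1cn([C@@H]2O[C@H](CO)[C@@H](O)[C@H]2O)c2ncnc(C)c12` gives 50 nM in an ADME assay on BJ cells (Homo sapiens), read by MTT assay, with a stated time of 72 h; a lower number here means a stronger inhibitor, a higher number a weaker inhibitor. Compound 2 `C#Cc1cn([C@@H]2O[C@H](CO)[C@@H](O)[C@H]2O)c2ncnc(N(C)C)c12` gives 410 nM in this assay, and compound 3 `C#Cc1cn([C@@H]2O[C@H](CO)[C@@H](O)[C@H]2O)c2ncnc(NC)c12` gives 86000 nM, the highest of the three numbers. The two steps leading up to that highest number are a 210-fold higher number from compound 2 to compound 3 (2.32 log units; beyond the scatter) and a 1700-fold higher number from compound 1 to compound 3 (3.24 log units; beyond the scatter). The remaining measured step is an 8.2-fold higher number from compound 1 to compound 2 (0.91 log units; beyond the scatter).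

Compound 4 `CNc1ncnc2c1c(-c1ccccc1)cn2[C@@H]1O[C@H](CO)[C@@H](O)[C@H]1O` keeps the methylamino group of compound 3 and changes a different part: phenyl in place of ethynyl on an aromatic carbon, on an aromatic carbon of the five-membered aromatic ring with one nitrogen, part of the fused system. Each of the three measured steps varies the methyl, dimethylamino or methylamino group, which compound 4 leaves untouched; none varies the ethynyl, so none bears on this change. With nothing to go on, the default expectation for compound 4 in this assay is no step beyond the scatter, no change at the digits printed from compound 3 to compound 4 (within the scatter), held with a wide range. Compound 4 is therefore estimated at 86000 nM, between 12000 nM and 400000 nM.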

Compound 4, half-maximal inhibitory concentration: > 100000 nM
Compound 4 gave a limit, no number; the forecaster's own chance of this, stated with the estimate: 30%; middle value at least 1.1-fold (0.06 log units) from the limit.
By their numbers in this assay, from the lowest: compound 1; then compound 2; then compound 3. At a limit, above all of these: compound 4.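

In this assay compound 4 gives > 100000 nM, a limit of the assay and not a number. Among the compounds shown, only compound 4 changes the group on this aromatic carbon of the five-membered aromatic ring, and swapping ethynyl for phenyl gives an at least 1.1-fold higher number from compound 3 to compound 4 (0.06 log units; that floor lies within the scatter). The step can be stated only as a floor, and its true size stays unknown, because compound 4 sits at the limit: the limit of > 100000 nM in this assay, at which 1 of the 4 values shown sits.

Compound 3 already has the highest number among the measured values, so this pair says little about how phenyl would behave on a compound with a lower number. Going by these compounds, whether the same change on compound 1, at 50 nM, would give a step of readable size remains open, as does the effect of a nitrile or an amine on this aromatic carbon.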